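Ethylsulfanyl in place of a short chain on compound 3

This account rests on a few compounds, and the source may have more. Where it says the series, first, only, none or still open, it means among the compounds named here.

Three compounds sharing one core were tested in a functional assay on the whole organism with Rattus norvegicus as the target, with a stated time of 4 h, at a dose of 40 mg/kg by the intraperitoneal route; on this read-out higher numbers stand for more inhibition at the one dose given (going by the name of the read-out) and lower numbers for less inhibition. Compound 1 `Cc1nc2c(C[S+]([O-])c3ccccc3)cccn2c1C` gives 42%, compound 2 `Cc1nc2c(OCc3ccccc3)cccn2c1CCC#N` gives 40%, and compound 3 `[C-]#[N+]Cc1c(C)nc2c(OCc3ccccc3)cccn12` gives 96%, the highest of the three, with gaps beyond the scatter to both others. Among the measured compounds shown here, the single measured one-place step, a number 56 percentage points higher from compound 2 to compound 3 (beyond the scatter), shows that swapping the chain on a saturated chain carbon bound to an aromatic carbon can move the read-out strongly. Compound 4 `CCSCc1c(C)nc2c(OCc3ccccc3)cccn12` arises from compound 3 by a group of 3 heavy atoms (2 carbon, 1 sulfur; no ring) in place of a group of 2 heavy atoms (1 carbon, 1 nitrogen; no ring), on a saturated chain carbon bound to an aromatic carbon. For the measured compounds named here, this runs in the opposite size direction to that measured step, so a fall in this assay is expected for compound 4, though no measured compound carries ethylsulfanyl. The estimate for compound 4 is 50%, between 20% and 85%, an expected step of a number 46 percentage points lower from compound 3 to compound 4 (beyond the scatter).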

Compound 4, a percentage reported as inhibition, in the whole organism at one dose (the size of the read-out at that dose, not a potency): 36%
Estimate against measurement, compound 4: 14 percentage points above, within the range that was stated.
By their numbers in this assay, from the lowest: compounds 4, 2 and 1 (each within the scatter of the next); then compound 3.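

In this assay, ethylsulfanyl on this saturated chain carbon bound to an aromatic carbon gives a number 60 percentage points lower from compound 3 to compound 4 (beyond the scatter), so the high number of compound 3 is lost with this change. Ethylsulfanyl in place of cyanomethyl gives a number 4 percentage points lower from compound 2 to compound 4 (within the scatter), so these two groups cannot be told apart here. Among the groups shown at this place, only the one on compound 3 goes with a high number. Nothing available explains the fall. On these data alone, whether an amine or a carboxylic acid at this place would keep the number of compound 3 remains open.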